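Amide to sulfonamide on the shared linker

This account rests on a few compounds, and the source may have more. Where it says the series, first, only, none or still open, it means among the compounds named here.

Three compounds of the series have been run in a functional assay on A-375 cells (Homo sapiens) for cytotoxicity, read by MTT assay; a lower number here means a stronger inhibitor, a higher number a weaker inhibitor. Compound 1 `O=C(NCCNc1nccc(-c2c(-c3cccc(F)c3)nc3sccn23)n1)c1ccc(C(F)(F)F)cc1` gives 8710 nM; compound 2 `O=C(NCCNc1nccc(-c2c(-c3cccc(F)c3)nc3sccn23)n1)c1ccccc1` gives 5060 nM; compound 3 `Cc1ccc(C(=O)NCCNc2nccc(-c3c(-c4cccc(F)c4)nc4sccn34)n2)cc1` gives 5880 nM. The three differ only in the substituent on the outer aromatic ring, and the steps between them are all small: a 1.7-fold lower number from compound 1 to compound 2 (0.24 log units; within the scatter), a 1.5-fold lower number from compound 1 to compound 3 (0.17 log units; within the scatter), a 1.2-fold higher number from compound 2 to compound 3 (0.07 log units; within the scatter). Compound 3 therefore sits among the other two without separating from either, its number closest to compound 2 and its gap to compound 1 still inside the scatter.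

Compound 4 `O=S(=O)(NCCNc1nccc(-c2c(-c3cccc(F)c3)nc3sccn23)n1)c1ccccc1` has not been measured. It is reached from compound 3 by a change at the linker rather than on the outer ring: phenylsulfonyl in place of (4-methylphenyl)carbonyl on an amine nitrogen. Among the compounds with values here, no measured pair in this set varies the carbonyl itself, so none of the three steps bears directly on the move to a sulfonyl; they only show that the outer-ring substituent has moved the number little. Within the data shown here, with no step of its own to lean on, compound 4 is expected to stay near compound 3, and the step of a 1.0-fold higher number from compound 3 to compound 4 (0.01 log units; within the scatter) is estimated to lie within the scatter, with a wide range to allow for the untested change. In this assay compound 4 is expected to give about 6000 nM, between 2500 nM and 15000 nM.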

Compound 4, half-maximal inhibitory concentration: 11000 nM
Compound 4: middle estimate off by 1.8-fold (0.26 log units), on the low side; measured number inside the range.
By their numbers in this assay, from the lowest: compounds 2, 3, 1 and 4 (each within the scatter of the next, the first and the last beyond it).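

Within the data shown here, on the amine nitrogen of the shared linker, the comparison with no substituent on the outer ring gives a 2.2-fold higher number from compound 2 to compound 4 (0.34 log units; beyond the scatter) in this assay, the first step in this set to lie beyond the scatter, though only modestly. Among these compounds, the other two comparisons do not show the same separation: a 1.9-fold higher number from compound 3 to compound 4 (0.27 log units; within the scatter) and a 1.3-fold higher number from compound 1 to compound 4 (0.10 log units; within the scatter) both stay within the scatter, so compounds 1 and 3 go against any general reading of this change and only the pair of compound 2 and compound 4 is separated. The outer-ring substituents, which earlier gave no separated pair, therefore leave the reading of the carbonyl to sulfonyl change dependent on the comparison chosen, and nothing measured here accounts for the step.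

Still open, as far as these compounds go, is whether a (4-methylphenyl)sulfonyl or (4-(trifluoromethyl)phenyl)sulfonyl group on the same nitrogen would follow its carbonyl counterpart, which would test the change with the outer ring held constant. Also open, from the compounds shown here alone, is how a urea, a methylsulfonyl group or a longer chain at this linker would read.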